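A few compounds are considered here, and "the series" means these few. Any claim that something is new, unique, unknown or untested is made for them only; others in the source may bear on it.

Measured so far:
- compound 1, `Cc1n[nH]c(-c2ncc3cccnc3c2O)n1`
- compound 2, `Cc1n[nH]c(-c2ncc3c(N4CCCCS4(=O)=O)ccnc3c2O)n1`

In a physicochemical assay for solubility, measured as kinetic solubility (a higher number here means a more soluble compound, a lower number a less soluble compound), compound 1 gives > 250000 nM, which is a limit of the assay and not a number. In this assay, for the measured compounds named here, compound 2 gives 250000 nM, the only plain number. The other entry is a limit of the assay, and compound 2 cannot be ranked against it. The step from compound 1 to compound 2 reads a number no higher from compound 1 to compound 2 (the limit leaves the size open). Going by these compounds, one of the two values sits at the limit of > 250000 nM in this assay, at which 1 of the 2 values shown sits, so the size of that step stays open.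

Compound 3, `COc1ccccc1-c1ccnc2c(O)c(-c3nc(C)n[nH]3)ncc12`, is not yet measured. It differs from compound 2 as follows: a group of 8 heavy atoms (7 carbon, 1 oxygen; one six-membered aromatic ring of carbon only) in place of a group of 8 heavy atoms (4 carbon, 1 nitrogen, 2 oxygen, 1 sulfur; one six-membered non-aromatic ring with 2 hetero atoms), on an aromatic carbon. Going by the values given here, no measured step bears on this exchange; the one step known, a number no higher from compound 1 to compound 2 (the limit leaves the size open), is of unreadable size and involves a different group entering rather than leaving. With no readable step to lean on, the expectation is set near the value of compound 2 with a wide range. Compound 3 is expected to give 100000 nM in this assay, with a range of 20000 nM to 250000 nM. The estimated step this implies is a 2.5-fold lower number from compound 2 to compound 3 (0.40 log units; beyond the scatter).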

Compound 3, solubility: > 250000 nM
Compound 3: a limit, no number (the forecaster's own chance of this, stated with the estimate: 25%); middle value at least 2.5-fold (0.39 log units) from the limit.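

In this assay compound 3 gives a limit of the assay and not a number, so the place opposite the ring nitrogen now holds 2-methoxyphenyl, with one six-membered aromatic ring of carbon only, and the read-out still stands at that limit. The exchange of the non-aromatic ring with 2 hetero atoms for 2-methoxyphenyl reads a number no lower from compound 2 to compound 3 (the limit leaves the size open), so no fall is seen with this change at this place. No step in the series can be read for size, because most of the values shown sit at the limit: the limit of > 250000 nM in this assay, at which 2 of the 3 values shown sit.

It remains open how far any of these compounds lies past the limit, and so whether hydrogen, 2-methoxyphenyl and the non-aromatic ring differ at all in this assay. Going by these compounds, it is also open whether an amine, a carboxylic acid or a longer carbon chain at this same place would give a plain number clear of the limit.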